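The compounds below may be only part of what the source reports. "The series", "measured", "known", "first", "only" and "open" are said of these compounds alone.

Compound 1 `Cc1noc(NS(=O)(=O)c2cccc([N+](=O)[O-])c2)c1C` is the starting point of this piece. In an assay on VSM-A10 cells for antagonist activity at Endothelin-1 receptor (Rattus norvegicus) (on this read-out higher numbers stand for weaker inhibition and lower numbers for stronger inhibition), compound 1 gives 7800 nM. Compound 3 `Cc1noc(NS(=O)(=O)c2ccc(NCC(=O)O)cc2)c1C` is its nearest neighbour: in this assay compound 3 gives 12000 nM, and the two numbers lie within the usual scatter of each other, so nothing separates them with confidence. Compound 2 `Nc1ccc(S(=O)(=O)Nc2noc3c2CCCC3)cc1` is a different case. In this assay compound 2 gives > 32000 nM, which is a limit rather than a number, the single such limit in this set: the limit of > 32000 nM in this assay, at which 1 of the 3 values shown sits. Among the measured compounds shown here, compound 1 therefore stands as one of only two compounds here with an actual number, and that number is not told apart from the one for compound 3.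

Compound 4 `Cc1noc(NS(=O)(=O)c2cccc(-c3ccccc3)c2)c1C` has not yet been measured. It differs from compound 1 in one place: phenyl in place of nitro on an aromatic carbon. Both the group that leaves and the one that enters sit on an aromatic carbon of a six-membered aromatic ring of carbon only, meta to a large group.

For the measured compounds named here, no measured pair in this set shares such a change, so there is no earlier step to lean on. The expectation for compound 4 in this assay is a modest move toward stronger inhibition, a step of a 2.6-fold lower number from compound 1 to compound 4 (0.41 log units; beyond the scatter). The number estimated for compound 4 in this assay is 3000 nM, with a range from 800 nM to 15000 nM.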

Compound 4, half-maximal inhibitory concentration: 5400 nM
Estimate against measurement, compound 4: 1.8-fold (0.26 log units) below; the range from low to high includes it.
By their numbers in this assay, from the lowest: compounds 4, 1 and 3 (each within the scatter of the next, the first and the last beyond it). At a limit, above all of these: compound 2.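

In this assay, phenyl in place of nitro on this aromatic carbon, meta to a large group, comes to a 1.4-fold lower number from compound 1 to compound 4 (0.16 log units; within the scatter), so compound 1 and compound 4 cannot be told apart on this read-out. Among the compounds shown here, this is the first step in the set that changes a single place, which the earlier compounds could not offer, and it shows that the position accepts a very different group with no clear gain or loss: phenyl brings 6 heavy atoms, one aromatic ring and 0 hydrogen-bond acceptors, while nitro has 3 heavy atoms, no ring and 2 hydrogen-bond acceptors. Nothing measured here explains why two such different groups read alike.

A single exchange at one position leaves open whether any group placed there can move the number beyond the usual scatter, and a nitrile, a methoxy group or a longer chain on this same aromatic carbon would test that. It also remains open whether phenyl would read the same way on another carbon of this ring, since the compounds shown hold it in this one place only.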